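Aminoquinoxaline series: assay notes on the benzylamine side group

A few compounds are considered here, and "the series" means these few. Any claim that something is new, unique, unknown or untested is made for them only; others in the source may bear on it.

Measured compounds and values in a functional assay on SW-620 cells (Homo sapiens) for inhibition, read by sulforhodamine B assay, with a stated time of 48 h; a lower number here means that less compound is tolerated, a higher number that more compound is tolerated:
- compound 1, `Nc1cc(N)c2nc(-c3ccccc3)c(Oc3ccc(Cl)c(Cl)c3)nc2c1`, gives 91200 nM
- compound 2, `Nc1cc(N)c2nc(-c3ccccc3)c(NCc3ccc(Cl)c(Cl)c3)nc2c1`, gives < 100000 nM, a limit of the assay
- compound 3, `COc1ccc(CNc2nc3cc(N)cc(N)c3nc2-c2ccccc2)cc1OC`, gives < 100000 nM, a limit of the assay

Compound 3 stands at the limit of this assay and not at a number. Compound 2 stands at the same limit. For the measured compounds named here, compound 1 is the only compound of the three with a read number, and it lies close to that limit. The step that the two limits leave unreadable from compound 2 to compound 3 is therefore unreadable: the two limits leave its size open. The shared picture is given by the limit of < 100000 nM in this assay, at which 2 of the 3 values shown sit, together with the value of compound 1.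

Compound 4, `Nc1cc(N)c2nc(-c3ccccc3)c(NCc3ccc(F)cc3)nc2c1`, is not yet measured. It differs from compound 3 in one place: 4-fluorophenyl in place of 3,4-dimethoxyphenyl on a saturated chain carbon bound to a nitrogen on an aromatic ring. Going by the values given here, only the step from compound 2 to compound 3 bears on a change at this position, and its size cannot be read. Among the compounds with values here, the change from compound 3 to compound 4 keeps the saturated chain carbon bound to the nitrogen on the aromatic ring and the rest of the core of compound 3, so no measured step gives a direction beyond the scatter in this assay.

Compound 4 is therefore expected to sit near the limit, with an estimated step that the limit leaves unreadable from compound 3 to compound 4 that is not expected to exceed the scatter. The estimate for compound 4 in this assay is 90000 nM, with a range from 40000 nM to 160000 nM.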

Compound 4, concentration lethal to 50% of the cells: < 100000 nM
Compound 4 gave a limit, no number (the forecaster's own chance of this, stated with the estimate: 50%); the middle value is on the limit's open side.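

In this assay compound 4 gives < 100000 nM, a limit of the assay and not a number. No step from compound 1, compound 2 or compound 3 to compound 4 can be read, and the shared picture stays: the limit of < 100000 nM in this assay, at which 3 of the 4 values shown sit.

Going by these compounds, the size of any effect of the substituted phenyl group on the saturated chain carbon remains open, with no read number for compound 2, compound 3 or compound 4.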